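Swapping pyridin-3-yl for pyridin-4-yl in compound 4

This account rests on a few compounds, and the source may have more. Where it says the series, first, only, none or still open, it means among the compounds named here.

- compound 1 `COC1=CC(=O)c2c(COc3ccc(C#N)cc3)c(C)n(C)c2C1=O`: 192 nM
- compound 2 `COC1=CC(=O)c2c(COc3ccccn3)c(C)n(C)c2C1=O`: 2390 nM
- compound 3 `COC1=CC(=O)c2c(COc3cccnc3)c(C)n(C)c2C1=O`: 1820 nM

These numbers come from a functional assay on MIA PaCa-2 cells (Homo sapiens) for cytotoxicity, read by MTT assay, with a stated time of 72 h; on this read-out lower numbers stand for stronger inhibition and higher numbers for weaker inhibition. Compound 3 sits level with compound 2, with a 1.3-fold lower number from compound 2 to compound 3 (0.12 log units; within the scatter). It is clearly weaker than compound 1, with a 9.5-fold higher number from compound 1 to compound 3 (0.98 log units; beyond the scatter). Compound 4 `COC1=CC(=O)c2c(COc3ccncc3)c(C)n(C)c2C1=O` keeps the shared core and has pyridin-4-yl in place of pyridin-3-yl on an oxygen on a saturated carbon. Among the measured compounds shown here, the closest precedent is the swap from pyridin-2-yl to pyridin-3-yl, which stayed within the scatter. The large steps, such as a 12-fold higher number from compound 1 to compound 2 (1.10 log units; beyond the scatter), replaced 4-cyanophenyl and are a different kind of change. No step beyond the scatter is therefore expected in this assay. The expected change is a 1.1-fold higher number from compound 3 to compound 4 (0.04 log units; within the scatter). For compound 4 the estimated value is 2000 nM, with an expected range from 900 nM to 4500 nM.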

Compound 4, half-maximal inhibitory concentration: 3270 nM
For compound 4 the middle estimate is 1.6-fold (0.21 log units) below the measured one; measured number inside the range.
By their numbers in this assay, from the lowest: compound 1; then compounds 3, 2 and 4 (each within the scatter of the next).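

In this assay, the change to pyridin-4-yl gives a 1.8-fold higher number from compound 3 to compound 4 (0.25 log units; within the scatter) and a 1.4-fold higher number from compound 2 to compound 4 (0.14 log units; within the scatter) so the three pyridine attachments on this oxygen cannot be told apart. The gap to 4-cyanophenyl persists for this third pyridine, with a 17-fold higher number from compound 1 to compound 4 (1.23 log units; beyond the scatter) in a step that confirms the separation from compound 1. Nothing measured here offers an explanation for that gap. Going by these compounds, what a plain phenyl or a 4-aminophenyl would give on this oxygen stays open, so how much of the gap belongs to the nitrile itself cannot be told.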